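A few compounds are considered here, and "the series" means these few. Any claim that something is new, unique, unknown or untested is made for them only; others in the source may bear on it.

Compound 2 `COc1cncc(-c2cccc(-c3cn4ccc(OC)c(C(N)=O)c4n3)c2)c1` shows the higher of the two numbers measured in a physicochemical assay for solubility, in phosphate buffer, with a stated time of 24 h, at pH 7.4; on this read-out higher numbers stand for higher solubility and lower numbers for lower solubility: compound 2 gives 40000 nM, while compound 1 `NC(=O)c1cccn2cc(-c3cccc(-c4cncc(OC[C@H]5CCCO5)c4)c3)nc12` gives 5300 nM, a gap beyond the usual scatter. Compound 3 `COc1ccn2cc(-c3cccc(-c4cncc(OC[C@H]5CCCO5)c4)c3)nc2c1C(N)=O` is not yet measured; it differs from compound 2 by oxolan-2-yl in place of hydrogen on a saturated chain carbon bound to an oxygen on an aromatic ring. For the measured compounds named here, no measured pair isolates this change, as compound 1 carries the larger group on a different core. A downward step is nonetheless expected, guided loosely by the lower number of compound 1 at 5300 nM. The step of a 2.7-fold lower number from compound 2 to compound 3 (0.43 log units; beyond the scatter) is expected to point down. Compound 3 is expected near 15000 nM, within 5000 nM to 40000 nM.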

Compound 3, solubility: 120000 nM
For compound 3 the middle estimate is 8.0-fold (0.90 log units) below the measured one; the measured number lies above the stated range.
By their numbers in this assay, from the lowest: compound 1; then compound 2; then compound 3.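

In this assay, extending the methoxy group to (oxolan-2-yl)methoxy does not lower the number: the change gives a 3.0-fold higher number from compound 2 to compound 3 (0.48 log units; beyond the scatter). Methoxy in place of hydrogen on an aromatic carbon of the core gives a 23-fold higher number from compound 1 to compound 3 (1.35 log units; beyond the scatter), so with the (oxolan-2-yl)methoxy group held constant, this single core change produces a large rise. Nothing measured here explains either step. From the compounds shown here alone, each change is seen only once, so it remains open whether either step would hold in another setting. Going by these compounds, it is also open whether an amine or a carboxylic acid in place of the oxolan-2-yl group would move the number the same way.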